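Meta substituent swap on the aryl ring: compound 4 estimated

The source may hold more compounds than are shown below. What is called first, only, known or untested is meant among the compounds shown, and "the series" means these compounds.

Measured so far:
compound 1 `Cc1nc(-c2ccc(Cl)s2)sc1COc1ccc2c(c1)OCC2CC(=O)O` – 8.34%
compound 2 `Cc1ccccc1-c1nc(C)c(COc2ccc3c(c2)OCC3CC(=O)O)s1` – 10.7%
compound 3 `Cc1cccc(-c2nc(C)c(COc3ccc4c(c3)OCC4CC(=O)O)s2)c1` – 47.2%

Compound 3 gives the highest number of the three in a functional assay on CHO cells for agonist activity at Free fatty acid receptor 1 (Homo sapiens), read by FLIPR and calcium flux, tested at 100 nM; a lower number here means a weaker effect, a higher number a stronger effect of the compound at the concentration tested. The step of a number 38.9 percentage points higher from compound 1 to compound 3 (beyond the scatter) and the step of a number 36.5 percentage points higher from compound 2 to compound 3 (beyond the scatter) both lie beyond the scatter, so compound 3 stands clearly above compound 1 and compound 2, whose own step a number 2.4 percentage points higher from compound 1 to compound 2 (within the scatter) lies within the scatter.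

Compound 4 `Cc1nc(-c2cccc(Cl)c2)sc1COc1ccc2c(c1)OCC2CC(=O)O` is not yet measured. It differs from compound 3 by chloro in place of methyl on an aromatic carbon; read one bond further out, the change is 3-methylphenyl to 3-chlorophenyl, the new group sitting meta to a large group. Among the compounds with values here, no measured step exchanges methyl for chloro at this place, so the expectation rests on the position alone: the large gains seen in a number 36.5 percentage points higher from compound 2 to compound 3 (beyond the scatter) and a number 38.9 percentage points higher from compound 1 to compound 3 (beyond the scatter) come with a 3-methylphenyl, and compound 4 keeps a group at that same position. A step within or slightly beyond the scatter, downward, is therefore expected, a number 7.2 percentage points lower from compound 3 to compound 4 (within the scatter). Compound 4 is estimated at 40%, between 15% and 70%.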

Compound 4, a percentage reported as activity, at one concentration (the size of the read-out at that concentration, not a potency): 43%
For compound 4 the middle estimate is 3 percentage points below the measured one; measured number inside the range.
By their numbers in this assay, from the lowest: compounds 1 and 2 (each within the scatter of the next); then compounds 4 and 3 (each within the scatter of the next).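

In this assay the step of a number 4.2 percentage points lower from compound 3 to compound 4 (within the scatter) shows that, at this place meta to a large group, chloro can stand in for methyl without a difference that can be told from the scatter, so the level of compound 3 is not tied to methyl alone. The steps of a number 32.3 percentage points higher from compound 2 to compound 4 (beyond the scatter) and a number 34.7 percentage points higher from compound 1 to compound 4 (beyond the scatter) show that a second 3-substituted phenyl also stands clear of the 2-methylphenyl and the 5-chlorothiophen-2-yl, which means that the high read-out seen so far is shared by both the 3-methylphenyl and the 3-chlorophenyl and is no longer a feature of a single compound. Nothing in the material at hand accounts for why methyl and chloro read alike here.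

The compounds shown leave open whether a larger or differently built group at this same place, such as methoxy, trifluoromethyl or nitrile, would keep the read-out at this level, and how a phenyl with no group there at all would compare. They also leave open whether chloro on the 2-position of the phenyl would stay as low as the 2-methylphenyl does, and the read-out at a single concentration gives no potency for any of these compounds.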